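Ether aryl change in the amide series: compound 3 to compound 4

A few compounds are considered here, and "the series" means these few. Any claim that something is new, unique, unknown or untested is made for them only; others in the source may bear on it.

The series shares an amide core; its members differ at the ether aryl group and at the substituent on the aniline ring. In an ADME assay on the whole organism (Mus musculus, strain CD1), read by LC-MS, using cassette dosing, with a stated time of 24 h, at a dose of 0.4 mg/kg by the intravenous route (a lower number here means less compound in the circulation, a higher number more compound in the circulation at the dose given), compound 1 `Cc1cn(-c2cc(CCS(N)(=O)=O)cc(NC(=O)c3ccc(C)c(Nc4nccc(-c5ccccc5)n4)c3)c2)cn1` gives 58.5 ng.h/mL, compound 2 `Cc1cn(-c2cc(NC(=O)c3ccc(C)c(Oc4ccccc4)c3)cc(C(F)(F)F)c2)cn1` gives 508 ng.h/mL, and compound 3 `Cc1cn(-c2cc(NC(=O)c3ccc(C)c(Oc4ccccc4)c3)cc(N3CCN(C)CC3)c2)cn1` gives 338 ng.h/mL. Compound 3 stands second highest of the three on this assay, nearest compound 2 and furthest from compound 1. Among the measured compounds shown here, the one single-point step measured so far, a 1.5-fold lower number from compound 2 to compound 3 (0.18 log units; within the scatter), touched the aniline substituent and not the ether aryl group.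

Compound 4 `Cc1cn(-c2cc(NC(=O)c3ccc(C)c(Oc4cccc5ccncc45)c3)cc(N3CCN(C)CC3)c2)cn1` is not yet measured. It differs from compound 3 by isoquinolin-8-yl in place of phenyl on an oxygen on an aromatic ring. For the measured compounds named here, no measured step touches this oxygen, so nothing in the data speaks for a change in either direction; the only measured step, from compound 2 to compound 3, stayed within the scatter. Compound 4 is therefore expected to land near compound 3, a step of a 1.1-fold lower number from compound 3 to compound 4 (0.05 log units; within the scatter) not beyond the scatter. The estimate for compound 4 in this assay is 300 ng.h/mL, with a range from 120 ng.h/mL to 750 ng.h/mL.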

Compound 4, area under the concentration-time curve: 128 ng.h/mL
The estimate for compound 4 lay 2.3-fold (0.37 log units) above the measured number; the measured number falls inside the stated range.
By their numbers in this assay, from the lowest: compound 1; then compound 4; then compounds 3 and 2 (each within the scatter of the next).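

Among the compounds shown here, the ether aryl group is the first place where a single change moves this assay beyond the scatter: isoquinolin-8-yl in place of phenyl on an oxygen on an aromatic ring gives a 2.6-fold lower number from compound 3 to compound 4 (0.42 log units; beyond the scatter). For the compounds shown here, the earlier step at the aniline substituent, a 1.5-fold lower number from compound 2 to compound 3 (0.18 log units; within the scatter), stayed within the scatter, so of the two places touched so far, only this one shows a change that can be read. Nothing in hand explains the lower number.

The compounds shown leave open whether the lower number follows the added carbon ring or the ring nitrogen; naphthyl and pyridinyl on the same oxygen would separate the two. Also open, on these data alone, is whether the change carries over when trifluoromethyl stands in place of 4-methylpiperazin-1-yl on the aniline ring.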